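From Phenyl to Thiophen-2-yl in a 4-Hydroxyphenyl Compound

The source may hold more compounds than are shown below. What is called first, only, known or untested is meant among the compounds shown, and "the series" means these compounds.

Compound 1 `Oc1cccc(-c2cc(-c3ccccc3)cc(-c3ccccc3)n2)c1`: 19300 nM
Compound 2 `Oc1cccc(-c2cc(-c3ccccc3)cc(-c3cccs3)n2)c1`: 18100 nM
Compound 3 `Oc1ccc(-c2cc(-c3ccccc3)cc(-c3ccccc3)n2)cc1`: 1300 nM

All three values come from a functional assay on MDA-MB-231 cells (Homo sapiens) for cytotoxicity, read by ELISA, with a stated time of 2 days (a lower number here means a stronger inhibitor, a higher number a weaker inhibitor), and the compounds differ only in the groups on a shared core. Compound 3 has the lowest number of the three (1300 nM), well under both compound 2 (18100 nM) and compound 1 (19300 nM).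

Compound 4 `Oc1ccc(-c2cc(-c3ccccc3)cc(-c3cccs3)n2)cc1` carries thiophen-2-yl in place of phenyl on an aromatic carbon next to the ring nitrogen (thiophen-2-yl in place of phenyl on an aromatic carbon). The same exchange has been measured once, with 3-hydroxyphenyl on the core, and there it stayed within the scatter (a 1.1-fold lower number from compound 1 to compound 2 (0.03 log units; within the scatter)). The other measured step (a 15-fold lower number from compound 1 to compound 3 (1.17 log units; beyond the scatter)) is large, but it exchanges 3-hydroxyphenyl for 4-hydroxyphenyl and does not involve the group changing here. One pair is thin evidence, and the thiophen-2-yl exchange has not yet been measured with 4-hydroxyphenyl on the core.

Resting on compound 2 (a 1.1-fold lower number from compound 1 to compound 2 (0.03 log units; within the scatter)), no step beyond the scatter is expected in this assay, and the estimated step is a 1.1-fold higher number from compound 3 to compound 4 (0.03 log units; within the scatter) and no more. For compound 4 the expected value is 1400 nM (estimated range 500 nM to 4000 nM).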

Compound 4, half-maximal inhibitory concentration: 2400 nM
Compound 4: the middle estimate sits 1.7-fold (0.23 log units) below what was measured; the measured number falls inside the stated range.
By their numbers in this assay, from the lowest: compounds 3 and 4 (each within the scatter of the next); then compounds 2 and 1 (each within the scatter of the next).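

With 4-hydroxyphenyl on the core, thiophen-2-yl in place of phenyl next to the ring nitrogen again leaves the number in this assay within the scatter, at a 1.8-fold higher number from compound 3 to compound 4 (0.27 log units; within the scatter), so the exchange that changed little on one core also changes little on a second, and the two steps agree: the same change on two cores in this assay, a 1.1-fold lower number (0.03 log units; within the scatter) from compound 1 to compound 2 and a 1.8-fold higher number (0.27 log units; within the scatter) from compound 3 to compound 4, 2.0-fold (0.29 log units) apart, within the scatter of two such steps

The 4-hydroxyphenyl exchange, seen earlier only with phenyl at this position, also holds with thiophen-2-yl there, at a 7.5-fold lower number from compound 2 to compound 4 (0.88 log units; beyond the scatter), and its size is in line with the earlier step: the same change on two cores in this assay, a 15-fold lower number (1.17 log units; beyond the scatter) from compound 1 to compound 3 and a 7.5-fold lower number (0.88 log units; beyond the scatter) from compound 2 to compound 4, 2.0-fold (0.29 log units) apart, within the scatter of two such steps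

Across these four compounds, then, the numbers divide by 4-hydroxyphenyl against 3-hydroxyphenyl and not by phenyl against thiophen-2-yl, and none of the four goes against this.

The compounds shown leave open whether a group of another kind at this position, such as an amine, a carboxylic acid or a longer alkyl chain, would move the number beyond the scatter. They also leave open whether the gain seen with 4-hydroxyphenyl would survive with a methoxy group in place of its hydroxyl.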